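The source may hold more compounds than are shown below. What is called first, only, known or untested is meant among the compounds shown, and "the series" means these compounds.

Measured compounds:
compound 1 `CCCCCCCCCc1cc2cn(COCCO)c(O)nc-2n1` – > 80000 nM
compound 2 `CCCCCCc1cc2cn(COCCO)c(=O)nc2o1` – >= 400000 nM

In a functional assay on HEL cells (Homo sapiens), read by microscopy (a lower number here means that less compound is tolerated, a higher number that more compound is tolerated), compound 1 gives > 80000 nM, which is a limit of the assay rather than a number. Compound 2 gives >= 400000 nM, also a limit. Compound 1 therefore stands at one of the two limits recorded (the limit of > 80000 nM in this assay, at which 1 of the 2 values shown sits); neither compound reached a measurable toxic concentration. Compound 3 `CCCCCCc1cc2cn(COCCO)c(O)nc-2n1` differs from compound 1 by hydrogen in place of propyl on a saturated chain carbon, six bonds along the chain from an aromatic carbon. Going by the values given here, no measured step of this kind is available, so in this assay a step from compound 1 to compound 3 beyond the scatter is not expected. Compound 3 is therefore estimated at 160000 nM, between 80000 nM and 400000 nM, an expected step that the limit leaves unreadable from compound 1 to compound 3.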

Compound 3, minimum cytotoxic concentration: > 400000 nM
Compound 3 was reported as a limit; the forecaster's own chance of this, stated with the estimate: 85%; at least 2.5-fold (0.39 log units) between middle value and limit.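

Going by these compounds alone, compound 1 and compound 3 both sit at limits in this assay, so no step between them can be read. The compounds shown leave open the concentration at which any becomes toxic, and whether hydrogen in place of propyl changes it.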